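The compounds below may be only part of what the source reports. "The series", "measured", "known", "first", "only" and "open" are said of these compounds alone.

Measured so far in a functional assay on Hs 683 cells (Homo sapiens) for inhibition, read by colorimetric assay and MTT assay, with a stated time of 72 h; a higher number here means a weaker inhibitor, a lower number a stronger inhibitor:
compound 1 `COc1ccc(-c2cc(NC(=S)NNC(=O)c3ccc(C)cc3)cs2)cc1` gives 30000 nM
compound 2 `Cc1ccc(C(=O)NNC(=S)Nc2csc(-c3ccccc3)c2)cc1` gives 37000 nM
compound 3 `COc1cc(C(=O)NNC(=S)Nc2csc(-c3ccccc3)c2)cc(OC)c1OC` gives 42000 nM

Compound 3 holds the highest of the three numbers, but all three lie within the scatter of one another, so no order among them is secured. Compound 4 `COc1cc(C(=O)NNC(=S)Nc2csc(-c3ccc(C)cc3)c2)cc(OC)c1OC` differs from compound 3 by methyl in place of hydrogen on an aromatic carbon on the phenyl attached to the shared core. Going by the values given here, the one measured step at that phenyl, a 1.2-fold higher number from compound 1 to compound 2 (0.09 log units; within the scatter), swapped methoxy for hydrogen and stayed within the scatter; no step with methyl at this position is known. The expectation for a 1.1-fold lower number from compound 3 to compound 4 (0.02 log units; within the scatter) is therefore no shift beyond the scatter. Compound 4 is estimated at 40000 nM, with a range from 20000 nM to 80000 nM.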

Compound 4, half-maximal inhibitory concentration: 42000 nM
Estimate against measurement, compound 4: 1.1-fold (0.02 log units) below, and the stated range covers the measured number.
By their numbers in this assay, from the lowest: compounds 1, 2, 3 and 4 (each within the scatter of the next).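

In this assay, the change from phenyl to 4-methylphenyl gives no change at the digits printed from compound 3 to compound 4 (within the scatter). Going by these compounds alone, this is the first reading of methyl at this position, and alongside a 1.2-fold higher number from compound 1 to compound 2 (0.09 log units; within the scatter) it makes two different changes on this phenyl that stay within the scatter. No measured information bears on this result.

Going by these compounds, whether an amine, a carboxylic acid or a longer chain in this place would give a step beyond the scatter remains open. The compounds shown also leave open whether any change on this phenyl can separate members of the series.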